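Methoxy for Dimethylamino on the Shared Core

This account rests on a few compounds, and the source may have more. Where it says the series, first, only, none or still open, it means among the compounds named here.

Measured compounds:
compound 1 `CN(C)c1ncnc2[nH]cc(Sc3cccs3)c12`, 3830 nM
compound 2 `c1csc(Sc2c[nH]c3ncnc(-c4cccs4)c23)c1`, 5140 nM

In a functional assay on K562 cells (Homo sapiens), read by MTT assay, with a stated time of 3 days (on this read-out higher numbers stand for weaker inhibition and lower numbers for stronger inhibition), compound 1 gives 3830 nM, and compound 2 gives 5140 nM in this assay; the step of a 1.3-fold higher number from compound 1 to compound 2 (0.13 log units; within the scatter) leaves the two indistinguishable. Compound 3 `COc1ncnc2[nH]cc(Sc3cccs3)c12` differs from compound 1 by methoxy in place of dimethylamino on an aromatic carbon. Going by the values given here, no measured step tests this exchange; the only measured step, a 1.3-fold higher number from compound 1 to compound 2 (0.13 log units; within the scatter), alters the same position without effect beyond the scatter. Compound 3 is therefore expected to show a 1.2-fold higher number from compound 1 to compound 3 (0.07 log units; within the scatter), with an estimate of 4500 nM and a range from 1500 nM to 13000 nM.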

Compound 3, half-maximal inhibitory concentration: > 50000 nM
Compound 3: no number, only a limit; the forecaster's own chance of this, stated with the estimate: 5%; middle value at least 11-fold (1.04 log units) from the limit.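

Compound 3 reaches only a limit, not a number: the limit of > 50000 nM in this assay, at which 1 of the 3 values shown sits. Even so, methoxy in place of dimethylamino gives an at least 13-fold higher number from compound 1 to compound 3 (1.11 log units; beyond the scatter), and methoxy in place of thiophen-2-yl gives an at least 9.7-fold higher number from compound 2 to compound 3 (0.98 log units; beyond the scatter). Dimethylamino and thiophen-2-yl had left the values within the scatter of each other, so this position now proves sensitive to the group it carries, and methoxy is the one change that separates from both. Left open is whether methylamino, ethoxy or a plain hydrogen on this carbon would read like compound 1 or like compound 3.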